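Replacing 2-chlorophenyl with 4-fluorophenyl in compound 2

The compounds below may be only part of what the source reports. "The series", "measured", "known", "first", "only" and "open" are said of these compounds alone.

In a functional assay on A549 cells (Homo sapiens) for antiproliferative activity, read by MTT assay, with a stated time of 24 h (on this read-out lower numbers stand for stronger inhibition and higher numbers for weaker inhibition), compound 1 `O=C(NNc1cccc(Cl)c1)c1ccc(NS(=O)(=O)c2cnc(O)nc2O)cc1` gives 7290 nM, while compound 2 `O=C(NNc1ccccc1Cl)c1cccc(NS(=O)(=O)c2cnc(O)nc2O)c1` gives 1460 nM, the lower of the two numbers, with a gap beyond the scatter. Compound 3 `O=C(NNc1ccc(F)cc1)c1cccc(NS(=O)(=O)c2cnc(O)nc2O)c1` remains unmeasured. It carries 4-fluorophenyl in place of 2-chlorophenyl on an amine nitrogen. For the measured compounds named here, no measured pair shows this change directly. Going by the values given here, with compound 2 at 1460 nM holding the lower of only two numbers, a modest move toward weaker inhibition is expected, near the edge of the scatter. The estimated step is a 1.7-fold higher number from compound 2 to compound 3 (0.23 log units; within the scatter). For compound 3 the expected value is 2500 nM, with an estimated range of 900 nM to 7000 nM.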

Compound 3, half-maximal inhibitory concentration: > 20000 nM
Compound 3 gave a limit, no number; the forecaster's own chance of this, stated with the estimate: 3%; middle value at least 8.0-fold (0.90 log units) away from the limit.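

In this assay, compound 3 gives a limit and not a number: the limit of > 20000 nM in this assay, at which 1 of the 3 values shown sits. On the amine nitrogen, putting 4-fluorophenyl in place of 2-chlorophenyl is therefore no minor exchange, as it produces an at least 13-fold higher number from compound 2 to compound 3 (1.13 log units; beyond the scatter). For the compounds shown here, this position, which no earlier pair differing in one place had tested, responds strongly to the change of aryl group.

The change alters both the halogen and its numbered position, and the compounds shown do not separate the two. On these data alone, whether 2-fluorophenyl, 4-chlorophenyl or plain phenyl would stay close to compound 2 remains open.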